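A Single Methyl on Compound 2

The source may hold more compounds than are shown below. What is called first, only, known or untested is meant among the compounds shown, and "the series" means these compounds.

In a functional assay on A549 cells (Homo sapiens) for antiproliferative activity, read by MTT assay (on this read-out lower numbers stand for stronger inhibition and higher numbers for weaker inhibition), compound 1 `COc1cc2c(Oc3ccc(NC(=O)Nc4ccc(Cl)c(C(F)(F)F)c4)cc3)ccnc2cc1OCCCCCCC(=O)NO` gives 5020 nM and compound 2 `COc1cc2c(Oc3ccc(NC(=O)NNC(=O)c4ccccc4)cc3)ccnc2cc1OCCCCCCC(=O)NO` gives 2820 nM. Among the compounds with values here, these are the only two numbers available, and they lie within the scatter of each other, so compound 2 stands level with compound 1. Within the data shown here, the one measured step, a 1.8-fold lower number from compound 1 to compound 2 (0.25 log units; within the scatter), puts benzamido in place of 4-chloro-3-(trifluoromethyl)phenyl on an amide-type nitrogen.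

Compound 3 `COc1cc2c(Oc3ccc(NC(=O)NNC(=O)c4cccc(C)c4)cc3)ccnc2cc1OCCCCCCC(=O)NO` departs from compound 2 by methyl in place of hydrogen on an aromatic carbon. This is methyl in place of hydrogen on an aromatic carbon, meta to a large group, which turns benzoyl into (3-methylphenyl)carbonyl. Among the measured compounds shown here, no measured step tests a methyl group at this place, so the evidence is indirect. For the measured compounds named here, the only guide is the exchange of a much larger group, and that step, a 1.8-fold lower number from compound 1 to compound 2 (0.25 log units; within the scatter), stayed within the scatter. No shift beyond the scatter is therefore expected in this assay, in either direction. The expected change is a 1.0-fold lower number from compound 2 to compound 3 (0.02 log units; within the scatter). For compound 3 the estimated value is 2700 nM, with an expected range from 1200 nM to 6000 nM.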

Compound 3, half-maximal inhibitory concentration: 8190 nM
The estimate for compound 3 lay 3.0-fold (0.48 log units) below the measured number, outside the stated range (above it).
By their numbers in this assay, from the lowest: compounds 2, 1 and 3 (each within the scatter of the next, the first and the last beyond it).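

In this assay, within the data shown here, the hydrogen on this aromatic carbon, meta to a large group, turns out not to be a silent place: adding one methyl, a single heavy atom with no ring, no charge and no hydrogen-bond donors or acceptors, gives a 2.9-fold higher number from compound 2 to compound 3 (0.46 log units; beyond the scatter), a modest loss of inhibition that the earlier compounds gave no sign of. Against the exchange of the whole end group the picture stays flat, since ((3-methylphenyl)carbonyl)amino in place of 4-chloro-3-(trifluoromethyl)phenyl gives a 1.6-fold higher number from compound 1 to compound 3 (0.21 log units; within the scatter), so the methyl moves compound 3 clearly away from compound 2 without separating it from compound 1. Nothing available here bears on why this methyl has this effect.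

The compounds shown leave open whether the change belongs to the methyl itself or to any group at this place, which a chlorine atom, a fluorine atom or a methoxy group on the same carbon would address. They also leave open whether a methyl on another carbon of this ring would give a step of the same size or none.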